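A few compounds are considered here, and "the series" means these few. Any claim that something is new, unique, unknown or untested is made for them only; others in the source may bear on it.

Of the compounds shown here, two have been measured in an ADME assay on L1210 cells (Mus musculus) for inhibition, read by cell counting; a higher number here means a weaker inhibitor, a lower number a stronger inhibitor. Compound 1, `CSc1nc(OCCCNc2ccnc3cc(Cl)ccc23)c(C#N)c(-c2ccccc2)n1`, gives 3900 nM in this assay. Going by the values given here, compound 2, `CSc1nc(NCCCCNc2ccnc3cc(Cl)ccc23)c(C#N)c(-c2cccc([N+](=O)[O-])c2)n1`, gives 2100 nM in this assay, and that number lies within the scatter of the one for compound 1, so the two cannot be told apart on this evidence. Compound 3, `CSc1nc(NCCCCNc2ccnc3cc(Cl)ccc23)c(C#N)c(-c2ccc(C)cc2)n1`, has not been measured; it differs from compound 2 by 4-methylphenyl in place of 3-nitrophenyl on an aromatic carbon. Among the compounds with values here, no pair of measured compounds differing in only one place is available, so there is no measured step to lean on. The expectation for the step from compound 2 to compound 3 in this assay is a small one, a 1.4-fold higher number from compound 2 to compound 3 (0.15 log units; within the scatter), toward a slightly higher number but not beyond the scatter. Compound 3 is therefore estimated to give 3000 nM in this assay, within a range from 1200 nM to 7500 nM.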

Compound 3, half-maximal inhibitory concentration: 4300 nM
Compound 3: middle estimate off by 1.4-fold (0.16 log units), on the low side, and the stated range covers the measured number.
By their numbers in this assay, from the lowest: compounds 2, 1 and 3 (each within the scatter of the next, the first and the last beyond it).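

In this assay, 4-methylphenyl in place of 3-nitrophenyl, on the aromatic carbon ortho to a cyano group, gives a 2.0-fold higher number from compound 2 to compound 3 (0.31 log units; beyond the scatter). Going by these compounds alone, this is the only comparison here between compounds differing in one place, and it shows that the group at this position can shift the number modestly, just past the usual scatter. Nothing measured here bears on why the number moves.

The compounds shown leave open whether the step follows the loss of the nitro group, the arrival of the methyl group or the change of place on the phenyl ring, as all three come together in this one exchange. Also open, on these data alone, is how this position would respond to 3-methylphenyl, 4-nitrophenyl, or a phenyl ring carrying an amine or a carboxylic acid.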